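The compounds below may be only part of what the source reports. "The series", "measured", "known", "first", "only" and "open" are said of these compounds alone.

For the measured compounds named here, compound 1 `O=c1c(C2N=C(c3ccccc3)SS2)coc2ccccc12` gives 16500 nM in a functional assay on IMR-32 cells (Homo sapiens) for inhibition, read by sulforhodamine B assay, with a stated time of 48 h (a lower number here means a stronger inhibitor, a higher number a weaker inhibitor), the lowest of the two numbers so far. Going by the values given here, compound 2 `O=c1c(C(=S)Nc2ccccc2)coc2cc(Cl)c(Cl)cc12` gives 89900 nM in this assay, a higher number beyond the scatter; the two structures differ in several places, so no single step is drawn between them. Compound 3 `O=c1c(C2N=C(c3ccccc3)SS2)coc2ccc(Cl)cc12` carries the change chloro in place of hydrogen on an aromatic carbon relative to compound 1. Among the compounds with values here, no measured pair isolates this change. A step of no more than the scatter is expected in this assay, with no clear direction. Compound 3 is therefore estimated at 14000 nM in this assay, between 5000 nM and 40000 nM, meaning an expected step of a 1.2-fold lower number from compound 1 to compound 3 (0.07 log units; within the scatter).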

Compound 3, half-maximal inhibitory concentration: 10000 nM
Compound 3: the middle estimate sits 1.4-fold (0.15 log units) above what was measured; the measured number falls inside the stated range.
By their numbers in this assay, from the lowest: compounds 3 and 1 (each within the scatter of the next); then compound 2.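

In this assay, chloro in place of hydrogen on this aromatic carbon of the shared core gives a 1.7-fold lower number from compound 1 to compound 3 (0.22 log units; within the scatter) and so stays within the scatter. This first single-place step in the series shows that the position takes a chlorine atom with no clear change in the number, though a step of this size sets no direction. No available evidence bears on this result. From the compounds shown here alone, whether an amine, a methoxy group or a carboxylic acid on the same carbon would give a step beyond the scatter remains open.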